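The compounds below may be only part of what the source reports. "The series", "measured", "known", "first", "only" and "open" are said of these compounds alone.

Three compounds of the series are in hand. Compound 1 `ClCc1ccc(Cn2cnc3c(Cl)ncnc32)cc1` gives 1250 nM in a functional assay on U-251 cells (Homo sapiens) for cytotoxicity, read by sulforhodamine B assay, with a stated time of 48 h; a higher number here means a weaker inhibitor of growth, a lower number a stronger inhibitor of growth. Compound 2 `ClCc1ccc(Cn2cnc3nc(Cl)nc(Cl)c32)cc1` gives 1770 nM in this assay, and compound 3 `ClCc1ccc(Cn2cnc3c(Cl)nc(Cl)nc32)cc1` gives 2040 nM in this assay. Compound 2 and compound 3 share the same atoms joined differently; the difference between the two cores is not broken down here, and their two values lie within the scatter of each other.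

The step hydrogen in place of chloro on an aromatic carbon gives a 1.6-fold lower number from compound 3 to compound 1 (0.21 log units; within the scatter).

Compound 4 `ClCc1ccc(Cn2cnc3ncnc(Cl)c32)cc1` is not yet measured. It differs from compound 2 by hydrogen in place of chloro on an aromatic carbon, the same change as from compound 3 to compound 1. The expected step of a 1.5-fold lower number from compound 2 to compound 4 (0.17 log units; within the scatter) rests on the earlier one, a 1.6-fold lower number from compound 3 to compound 1 (0.21 log units; within the scatter), taken as a guide. Compound 4 is therefore estimated at 1200 nM, within 600 nM to 2500 nM, in this assay.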

Compound 4, concentration for 50% growth inhibition: 1090 nM
Estimate against measurement, compound 4: 1.1-fold (0.04 log units) above, and the stated range covers the measured number.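

In this assay, hydrogen in place of chloro on an aromatic carbon gives a 1.6-fold lower number from compound 2 to compound 4 (0.21 log units; within the scatter). Set beside the earlier step, the change reads alike on both cores: the same change on two cores in this assay, a 1.6-fold lower number (0.21 log units; within the scatter) from compound 3 to compound 1 and a 1.6-fold lower number (0.21 log units; within the scatter) from compound 2 to compound 4, 1.0-fold (0.00 log units) apart, within the scatter of two such steps. For the compounds shown here, this shows only that the two steps agree on these two cores; each lies within the scatter, so it does not show that removing this chloro group alters growth inhibition on either core, and two cores set no rule for any other.

Open, on these data alone, is what an amine, a methoxy group or a longer chain would give in place of chloro on the aromatic carbon. Also open, as far as these compounds go, is what a hydroxymethyl group would give in place of the chloromethyl group shared by all four compounds.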